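The source may hold more compounds than are shown below. What is called first, only, known or untested is meant among the compounds shown, and "the series" means these compounds.

Working notes on the alkyne series of phenylpropanoic and related acids.

Three compounds of the series have been run in an in vitro functional assay on 1321-N1 cells for agonist activity at Free fatty acid receptor 1 (Homo sapiens), read by fluorescence, spectrophotometry and calcium flux; on this read-out higher numbers stand for an effect only at larger amounts of compound and lower numbers for an effect already at smaller amounts. Compound 1, `O=C(O)C1CC1c1ccc(C#Cc2cc(Cl)nc(Cl)c2)cc1`, gives 42.7 nM. Compound 2, `O=C(O)CCc1ccc(C#Cc2ccnc(F)c2)cc1`, gives 513 nM. Compound 3, `O=C(O)CCc1ccc(C#Cc2ncccc2[N+](=O)[O-])cc1`, gives 11000 nM. Compound 2 thus holds the second highest of the three numbers: it sits closer to compound 1, with a gap beyond the scatter, and further from compound 3, with a gap also beyond the scatter.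

The next compound, compound 4, `Cc1cc(C#Cc2ccc(CCC(=O)O)cc2)ccn1`, is yet to be measured in this assay. It differs from compound 2 in one place: methyl in place of fluoro on an aromatic carbon. The group that leaves and the group that enters each count one heavy atom, and neither brings a donor, an acceptor or a charge.

Within the data shown here, no measured pair separates this change on its own, so there is no direct step to draw on. The step from compound 2 to compound 4 is expected to be small, within the scatter, at a 1.3-fold lower number from compound 2 to compound 4 (0.11 log units; within the scatter). Compound 4 is estimated at 400 nM, in the range 150 nM to 1500 nM.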

Compound 4, half-maximal effective concentration: 1120 nM
The estimate for compound 4 lay 2.8-fold (0.45 log units) below the measured number; the measured number falls inside the stated range.
By their numbers in this assay, from the lowest: compound 1; then compound 2; then compound 4; then compound 3.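

In this assay, among these compounds, the position next to the ring nitrogen is sensitive to the choice of substituent: methyl in place of fluoro on an aromatic carbon gives a 2.2-fold higher number from compound 2 to compound 4 (0.34 log units; beyond the scatter) and is the first step that isolates a single change. Fluoro and methyl each count one heavy atom, and neither brings a donor, an acceptor or a charge, yet the two are not interchangeable at this position, and the lower number stays with fluoro. No measurement at hand accounts for this step.

On these data alone, whether a methoxy group, an amine or a trifluoromethyl group at this position would read closer to fluoro or to methyl remains open. Also open, as far as these compounds go, is whether the same change would give a similar step on the core of compound 1.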